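A few compounds are considered here, and "the series" means these few. Any claim that something is new, unique, unknown or untested is made for them only; others in the source may bear on it.

In an assay on isolated protein (urine) for inhibition of Myeloperoxidase (Homo sapiens), with a stated time of 5 min (a higher number here means a weaker inhibitor, a lower number a stronger inhibitor), the measured compounds gave the following numbers.
Compound 1 `NCCCc1c[nH]c2c(F)cccc12`: 24 nM
Compound 2 `CCCc1c[nH]c2ccc(F)cc12`: > 100 nM, a limit of the assay rather than a number
Compound 3 `CNC(=O)CCCc1c[nH]c2ccc(F)cc12`: 40 nM

Compound 3 and compound 1 give numbers whose gap lies within the scatter, so the two cannot be set apart. The value of compound 2 is a limit and nothing more can be said of it. Within the data shown here, the one measured step is an at least 2.5-fold lower number from compound 2 to compound 3 (0.39 log units; beyond the scatter), where the number left the limit of > 100 nM in this assay, at which 1 of the 3 values shown sits, and came down to the value of compound 3.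

Compound 4 `CCSCCc1c[nH]c2ccc(F)cc12` differs from compound 3 by ethylsulfanyl in place of (methylcarbamoyl)methyl on a saturated chain carbon, two bonds along the chain from an aromatic carbon. This change largely undoes what the step to compound 3 did: the amide is gone and a short chain carrying a sulfur remains, which brings compound 4 closer in build to compound 2 than to compound 3. The expectation for the step to compound 4 in this assay is therefore a rise of the number, of about the size seen in reverse, a 3.0-fold higher number from compound 3 to compound 4 (0.48 log units; beyond the scatter). Compound 4 is accordingly estimated at 120 nM, within a range from 40 nM to 400 nM, with a fair chance that only a limit is reported.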

Compound 4, half-maximal inhibitory concentration: > 100 nM
Compound 4: a limit, no number (the forecaster's own chance of this, stated with the estimate: 50%); the middle value lies beyond the limit too.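

Replacing (methylcarbamoyl)methyl with ethylsulfanyl on a saturated chain carbon, two bonds along the chain from an aromatic carbon, gives an at least 2.5-fold higher number from compound 3 to compound 4 (0.39 log units; beyond the scatter) in this assay, so the number at this part of the chain now moves in both directions with the group it carries. Compound 4 gives > 100 nM, a limit of the assay and not a number. The step from compound 2 to compound 4 cannot be read, so the ethylsulfanyl chain and the chain of compound 2 stay unranked, and both compounds rest on the same limit: the limit of > 100 nM in this assay, at which 2 of the 4 values shown sit.

The change from compound 3 to compound 4 removes the amide and brings in sulfur in one move, so the compounds shown do not tell which of these goes with the higher number, nor how far the number rises beyond the limit. On these data alone, it also stays open how the number would respond to a carboxylic acid, an ether oxygen in place of the sulfur, or a longer chain ending in a methylcarbamoyl group on the same core.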